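A few compounds are considered here, and "the series" means these few. Any claim that something is new, unique, unknown or untested is made for them only; others in the source may bear on it.

Working notes on the series. In a functional assay on HEK293 cells for agonist activity at Neuronal acetylcholine receptor; alpha4/beta2 (Homo sapiens), read by FLIPR (on this read-out higher numbers stand for an effect only at larger amounts of compound and lower numbers for an effect already at smaller amounts), compound 1 `c1cncc(N2CC[C@@H]3CN[C@@H]3C2)c1` gives 330 nM, compound 2 `COc1cncc(N2CC[C@H]3CN[C@H]3C2)c1` gives 130 nM, and compound 3 `COc1cncc(N2CC[C@@H]3CN[C@@H]3C2)c1` gives 2700 nM. Compound 3 thus carries the highest number of the three in this assay: the step of an 8.2-fold higher number from compound 1 to compound 3 (0.91 log units; beyond the scatter) is modest, the step of a 21-fold higher number from compound 2 to compound 3 (1.32 log units; beyond the scatter) is large, and the latter rests on (the fact that compounds 2 and 3 differ only in the configuration as drawn). Compound 4 `N/C(=N/O)c1cncc(N2CC[C@@H]3CN[C@@H]3C2)c1` keeps the configuration drawn for compound 3 and changes only the substituent: a group of 4 heavy atoms (1 carbon, 2 nitrogen, 1 oxygen; no ring) in place of a group of 2 heavy atoms (1 carbon, 1 oxygen; no ring), on an aromatic carbon. Among the measured compounds shown here, no measured step exchanges this substituent with the configuration held; the only measured step at this position is an 8.2-fold higher number from compound 1 to compound 3 (0.91 log units; beyond the scatter), which tells how far hydrogen and methoxy stand apart on this core, and nothing measured tells where the entering group falls in this assay. Compound 4 is therefore expected to stay in the neighbourhood of the number seen for compound 3. The estimate for compound 4 is 1500 nM, within a wide range from 300 nM to 8000 nM. The step of a 1.8-fold lower number from compound 3 to compound 4 (0.26 log units; within the scatter) implied by this estimate is expected to be small and not clearly beyond the scatter.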

Compound 4, half-maximal effective concentration: 180 nM
Estimate against measurement, compound 4: 8.3-fold (0.92 log units) above; measured number outside the range, below it.
By their numbers in this assay, from the lowest: compounds 2, 4 and 1 (each within the scatter of the next, the first and the last beyond it); then compound 3.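

On the configuration of compound 3, a 15-fold lower number from compound 3 to compound 4 (1.18 log units; beyond the scatter) in this assay shows that the high number of compound 3 goes with methoxy specifically and not with any substituent on this aromatic carbon. Against hydrogen on the same core, the entering group, which carries 2 hydrogen-bond donors and is larger than methoxy, gives a 1.8-fold lower number from compound 1 to compound 4 (0.26 log units; within the scatter) and so leaves the number where hydrogen has it. Nothing at hand bears on the cause of either step.

On these data alone, how the entering group behaves on the mirror-image configuration of compound 2, the form on which methoxy gives the lower number, stays open. As far as these compounds go, it is also open whether an amine, a carboxylic acid or a longer alkyl chain on this aromatic carbon would fall with hydrogen and the entering group or with methoxy.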